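A few compounds are considered here, and "the series" means these few. Any claim that something is new, unique, unknown or untested is made for them only; others in the source may bear on it.

Compound 1 `CC(C)c1ncc([C@@H](CCCCCCc2ccc3c(n2)NCCC3)CC(=O)O)cn1`: "not determined" (no result reported)
Compound 2 `O=C(O)C[C@H](CCCCCCc1ccc2c(n1)NCCC2)c1cncnc1`: 6.4 h

Within the data shown here, in an in vivo ADME assay on the whole organism (Canis lupus familiaris) for metabolic stability (a higher number here means that the compound lasts longer, a lower number that the compound disappears faster), compound 2 at 6.4 h holds the only number, with no result for compound 1, so no measured step is available as a guide. Compound 3 `COc1ncc([C@@H](CCCCCCc2ccc3c(n2)NCCC3)CC(=O)O)cn1` carries the change (methoxy in place of hydrogen on an aromatic carbon), which turns pyrimidin-5-yl into 2-methoxypyrimidin-5-yl: methoxy in place of hydrogen on an aromatic carbon. In this assay, no change beyond the scatter is expected, with a slight drift downward at most. The expected step is a 1.2-fold lower number from compound 2 to compound 3 (0.07 log units; within the scatter). The estimate for compound 3 is 5.5 h, with an expected range of 2.5 h to 11 h.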

Compound 3, half-life: 6.8 h
The estimate for compound 3 lay 1.2-fold (0.09 log units) below the measured number; the range from low to high includes it.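

In this assay, methoxy in place of hydrogen on the aromatic carbon between two ring nitrogen atoms gives a 1.1-fold higher number from compound 2 to compound 3 (0.03 log units; within the scatter) and so, in this one pair, the position takes a methoxy without a step beyond the scatter. Nothing measured here accounts for this result. Compound 1 has no number, and steps to it cannot be read. As far as these compounds go, whether an amine or a nitrile on the same aromatic carbon would also stay within the scatter remains open.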